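The compounds below may be only part of what the source reports. "The series", "measured", "known", "first", "only" and "open" are said of these compounds alone.

Measured so far in a functional assay on CHO cells for antagonist activity at growth hormone secretagogue receptor type 1 (Homo sapiens); on this read-out lower numbers stand for stronger inhibition and higher numbers for weaker inhibition:
- compound 1 `CCc1ccc(Cn2c(CCc3ccccc3)nnc2[C@H](NC(=O)c2ccccn2)c2c[nH]c3ccccc23)cc1` gives 513 nM
- compound 2 `CCc1ccc(Cn2c(CCc3ccccc3)nnc2[C@H](NC(=O)c2ccncc2)c2c[nH]c3ccccc23)cc1` gives "not determined" (no result reported); no number was reported for it
- compound 3 `COc1ccc(-n2c(CCc3ccccc3)nnc2[C@H](NC(=O)Cc2ccccn2)c2c[nH]c3ccccc23)c(OC)c1` gives 35 nM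

Compound 3 stands at the lowest of the two numbers in this assay. Its nearest neighbour is compound 1, which gives 513 nM in this assay, and the gap between the two lies beyond the usual scatter. Compound 2 contributes no number to the comparison.

Compound 4 `CCc1ccc(Cn2c(CCc3ccccc3)nnc2[C@H](NC(=O)Cc2ccccn2)c2c[nH]c3ccccc23)cc1` differs from compound 3 in one place: 4-ethylbenzyl in place of 2,4-dimethoxyphenyl on an aromatic nitrogen. Among the measured compounds shown here, no pair of measured compounds separated by this change alone is available, so the size of the step cannot be read from a measured pair; it has to be estimated. In this assay compound 1 carries the same 4-ethylbenzyl group and sits at the higher number, so the expectation for compound 4 is a number above that of compound 3, with a step of a 4.3-fold higher number from compound 3 to compound 4 (0.63 log units; beyond the scatter) expected in this assay. Compound 4 is estimated to give 150 nM in this assay, within a range from 40 nM to 600 nM.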

Compound 4, antagonist equilibrium constant: 124 nM
Compound 4: the middle estimate sits 1.2-fold (0.08 log units) above what was measured, within the range that was stated.
By their numbers in this assay, from the lowest: compound 3; then compound 4; then compound 1.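

In this assay the group on the aromatic nitrogen can now be read on its own, with the group on the carbonyl carbon held constant: a 3.5-fold higher number from compound 3 to compound 4 (0.55 log units; beyond the scatter) when 4-ethylbenzyl replaces 2,4-dimethoxyphenyl. Among the compounds shown here, the carbonyl side can also be read for the first time, with 4-ethylbenzyl held constant: a 4.1-fold lower number from compound 1 to compound 4 (0.62 log units; beyond the scatter) when (pyridin-2-yl)methyl replaces pyridin-2-yl, so the number responds to changes in both places, each beyond the scatter. Nothing measured here gives a reason for either step.

As far as these compounds go, it remains open whether the step on the aromatic nitrogen keeps its size when pyridin-2-yl sits on the carbonyl carbon. Also open, from the compounds shown here alone, is how a longer chain such as 2-(pyridin-2-yl)ethyl, or an amine in place of the pyridine ring, would read on the carbonyl carbon.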